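This account rests on a few compounds, and the source may have more. Where it says the series, first, only, none or still open, it means among the compounds named here.

Compound 1, `Nc1scc(CN2CCN(c3ccc(Cl)cc3Cl)CC2)c1C(=O)c1ccc(Cl)cc1`, gives -11%. Compound 2, `Nc1scc(CN2CCN(c3cccc(Cl)c3Cl)CC2)c1C(=O)c1ccc(Cl)cc1`, gives 3.2%. Compound 3, `Nc1scc(CN2CCN(c3ccc([N+](=O)[O-])cc3)CC2)c1C(=O)c1ccc(Cl)cc1`, gives -13%.

In a functional assay on CHO cells with adenosine receptor A1 (Homo sapiens) as the target, read by cAMP accumulation and immunoassay, with a stated time of 6 min, tested at 0.1 uM (on this read-out higher numbers stand for a weaker effect at the one concentration tested and lower numbers for a stronger effect), compound 3 sits within the scatter of compound 1, while the step of a number 16.2 percentage points lower from compound 2 to compound 3 (beyond the scatter) is beyond it. Compound 4, `Nc1scc(CN2CCN(c3ccc(OC(F)(F)F)cc3)CC2)c1C(=O)c1ccc(Cl)cc1`, is not yet measured. The change from compound 3 to compound 4 is trifluoromethoxy in place of nitro on an aromatic carbon. The two measured steps that touch the same aryl group, a number 2 percentage points lower from compound 1 to compound 3 (within the scatter) and a number 16.2 percentage points lower from compound 2 to compound 3 (beyond the scatter), show a modest swing at most and none for a change at this position. A step of a number 3 percentage points higher from compound 3 to compound 4 (within the scatter) is therefore expected, within the scatter. Compound 4 is estimated at -10% in this assay, between -25% and 8%.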

Compound 4, a percentage reported as activity, at one concentration (the size of the read-out at that concentration, not a potency): -13%
For compound 4 the middle estimate is 3 percentage points above the measured one; the measured number falls inside the stated range.
By their numbers in this assay, from the lowest: compounds 3, 4 and 1 (each within the scatter of the next); then compound 2.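

In this assay, trifluoromethoxy in place of nitro on an aromatic carbon gives no change at the digits printed from compound 3 to compound 4 (within the scatter), the first direct exchange measured at this position, and it leaves the read-out within the scatter. The other two steps, a number 16.2 percentage points lower from compound 2 to compound 4 (beyond the scatter) and a number 2 percentage points lower from compound 1 to compound 4 (within the scatter), match those of compound 3, so compound 2 remains the only one set apart from the others. Nothing available explains this result.

The compounds shown leave open whether an amine or a carboxylic acid on this aromatic carbon would also stay within the scatter of compound 3.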